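The compounds below may be only part of what the source reports. "The series", "measured", "known", "first", "only" and "open" are said of these compounds alone.

For the measured compounds named here, in a functional assay on HT-29 cells (Homo sapiens) for cytotoxicity, read by MTT assay, with a stated time of 72 h (a lower number here means a stronger inhibitor of growth, a higher number a weaker inhibitor of growth), compound 2, `CSc1nc(NCc2ccccc2)c2ccccc2n1`, gives 36500 nM, the only plain number among the two values shown. Compound 1, `CSc1nc(NCc2ccc([Se]C)cc2)c2ccccc2n1`, reports only a limit of > 100000 nM (the limit of > 100000 nM in this assay, at which 1 of the 2 values shown sits). The measured step of an at least 2.7-fold lower number from compound 1 to compound 2 (0.43 log units; beyond the scatter) is the one that bears here. Compound 3, `CSc1ccc(CNc2nc(SC)nc3ccccc23)cc1`, differs from compound 2 by methylsulfanyl in place of hydrogen on an aromatic carbon, a change of the same kind as that step run in reverse. A weaker number is therefore expected, and the limit may be reached again. Compound 3 is estimated at 100000 nM, between 40000 nM and 300000 nM, an expected step of a 2.7-fold higher number from compound 2 to compound 3 (0.44 log units; beyond the scatter).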

Compound 3, concentration for 50% growth inhibition: 34700 nM
Estimate against measurement, compound 3: 2.9-fold (0.46 log units) above; measured number outside the range, below it.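

At the aromatic carbon para to a large group, methylsulfanyl in place of hydrogen gives a 1.1-fold lower number from compound 2 to compound 3 (0.02 log units; within the scatter), so in this assay a group of this size at this carbon need not weaken growth inhibition. Exchanging selenium for sulfur within that group gives an at least 2.8-fold lower number from compound 1 to compound 3 (0.45 log units; beyond the scatter), so the two groups do not behave alike here. Compound 1 remains a limit of the assay, not a number: the limit of > 100000 nM in this assay, at which 1 of the 3 values shown sits.

On these data alone, the true size of that exchange stays open. So does whether an amine, a carboxylic acid or a longer chain at this carbon would move the number beyond the scatter.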